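The compounds below may be only part of what the source reports. "The series", "measured", "known", "first", "only" and "open" are said of these compounds alone.

Compounds measured so far:
compound 1, `O=C1C(Nc2ccccc2)=CC(=O)c2c1nc1n2[C@H]2OC[C@@H](O)[C@H]2OC1`: > 8000 nM in a functional assay on HeLa cells (Homo sapiens) for inhibition, read by sulforhodamine B assay (on this read-out lower numbers stand for stronger inhibition and higher numbers for weaker inhibition), a limit of the assay
compound 2, `O=C1C=C(NC2CCCCC2)C(=O)c2c1nc1n2[C@H]2OC[C@@H](O)[C@H]2OC1`: > 16000 nM, also a limit
compound 3, `COc1ccccc1NC1=CC(=O)c2nc3n(c2C1=O)[C@H]1OC[C@@H](O)[C@H]1OC3`: 2950 nM

Compound 1 therefore stands at the limit of > 8000 nM in this assay, at which 1 of the 3 values shown sits, and has no number of its own. Compound 2 likewise sits at the limit (the limit of > 16000 nM in this assay, at which 1 of the 3 values shown sits). Only compound 3 gives a number. Compound 4, `O=C1C(NC2CCCCC2)=CC(=O)c2c1nc1n2[C@H]2OC[C@@H](O)[C@H]2OC1`, differs from compound 1 by cyclohexyl in place of phenyl on an amine nitrogen. Going by the values given here, the single measured step that bears on this change runs the other way: an at least 5.4-fold lower number from compound 2 to compound 3 (0.73 log units; beyond the scatter), with the aryl group replacing cyclohexyl and giving the lower number. Reversed, cyclohexyl in place of phenyl should, if anything, raise the number in this assay. Compound 4 is thus expected to remain beyond the limit, a step that the limit leaves unreadable from compound 1 to compound 4. The estimate for compound 4 is 20000 nM, in the range 8000 nM to 60000 nM, most likely reported only as a limit.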

Compound 4, half-maximal inhibitory concentration: > 16000 nM
Compound 4 was reported as a limit; the forecaster's own chance of this, stated with the estimate: 85%; the middle value lies beyond the limit too.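

Compound 1 and compound 4 are both reported only as limits in this assay, so the step between them, anilino to cyclohexylamino, cannot be read. The compounds shown leave open how far beyond its limit either compound lies.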